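The compounds below may be only part of what the source reports. "The series", "measured", "known", "first", "only" and "open" are said of these compounds alone.

Compound 1 `CC(C)CNC(=O)n1c(=O)oc2ccc(C3CCN(C)CC3)cc21`: 0.667 h
Compound 2 `CC(=O)N1CCC(c2ccc3c(c2)oc(=O)n3C(=O)NCCCCc2ccccc2)CC1`: 1 h
Compound 3 `O=C(NCCCCc1ccccc1)n1c2c(oc1=O)CNCC2`: < 0.25 h, a limit of the assay

Within the data shown here, in an ADME assay on microsomes from liver (Mus musculus) for metabolic stability, read by LC-MS, using NADPH, with stated times of 15 min and 60 min, tested at 4.6 uM (a higher number here means that the compound lasts longer, a lower number that the compound disappears faster), compound 2 gives 1 h, within the scatter of the only other number, that of compound 1. Compound 3 gives only a limit. Compound 4 `CC(C)CN1CCC(c2ccc3c(c2)oc(=O)n3C(=O)NCCCCc2ccccc2)CC1` carries isobutyl in place of acetyl on an amine nitrogen in a ring. Among the measured compounds shown here, no measured pair isolates this change. Compound 1 has no acetyl on that nitrogen and still gives 0.667 h, so no large step is expected. The expected change is a slight fall, within the scatter, an estimated 1.7-fold lower number from compound 2 to compound 4 (0.22 log units; within the scatter). For compound 4 the estimate is 0.6 h, with an expected range of 0.25 h to 1.3 h.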

Compound 4, half-life: 1 h
Beside the measured number, compound 4's estimate is 1.7-fold (0.22 log units) below it; measured number inside the range.
By their numbers in this assay, from the lowest: compounds 1, 2 and 4 (each within the scatter of the next). At a limit, below all of these: compound 3.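

In this assay, among these compounds, this is the first pair that differs in one place, and it reads no change at the digits printed from compound 2 to compound 4 (within the scatter) for isobutyl in place of acetyl on an amine nitrogen in a ring. At this position, then, the number tolerates the loss of the acetyl group with its carbonyl and hydrogen-bond acceptor. Nothing shown here gives a cause for this.

On these data alone, a carboxylic acid or a longer chain on that nitrogen remains open. So does whether the same change reads alike with the shorter isobutyl side chain of compound 1, since a single pair carries it.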